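A Hydroxypiperidine Sulfonamide in Place of the Trifluoromethylpyridine

The source may hold more compounds than are shown below. What is called first, only, known or untested is meant among the compounds shown, and "the series" means these compounds.

Compound 2 `O=C(NCc1ccc(S(=O)(=O)c2cncc(C(F)(F)F)c2)cc1)N1Cc2ccncc2C1` was measured in an assay on isolated protein for inhibition of Nicotinamide phosphoribosyltransferase (Homo sapiens), read by mass spectrometry, with stated times of 15 min and 30 min (a lower number here means a stronger inhibitor, a higher number a weaker inhibitor), and gave 15 nM. Among the three compounds measured so far it stands second highest. Compound 1 `O=C(NCc1ccc(S(=O)(=O)c2cccc(C(F)(F)F)c2)cc1)N1Cc2ccncc2C1` gives 8 nM in this assay, and the step of a 1.9-fold higher number from compound 1 to compound 2 (0.27 log units; within the scatter) lies within the scatter, so the two are not told apart. Compound 3 `CC(=O)N1CCC(S(=O)(=O)c2ccc(CNC(=O)N3Cc4ccncc4C3)cc2)CC1` gives 83 nM in this assay; the step of a 5.5-fold higher number from compound 2 to compound 3 (0.74 log units; beyond the scatter) and the step of a 10-fold higher number from compound 1 to compound 3 (1.02 log units; beyond the scatter) both lie beyond the scatter.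

Compound 4 `O=C(NCc1ccc(S(=O)(=O)N2CCC(O)CC2)cc1)N1Cc2ccncc2C1` has not yet been measured. It differs from compound 2 in one place: 4-hydroxypiperidin-1-yl in place of 5-(trifluoromethyl)pyridin-3-yl on a sulfonyl sulfur. The step that bears most directly on it is a 5.5-fold higher number from compound 2 to compound 3 (0.74 log units; beyond the scatter), where a six-membered aromatic ring on the sulfonyl sulfur gave way to a six-membered non-aromatic ring, and the step of a 10-fold higher number from compound 1 to compound 3 (1.02 log units; beyond the scatter) points the same way. Among the measured compounds shown here, the present change likewise replaces the aromatic ring with a six-membered non-aromatic ring, this time carrying one hydrogen-bond donor, a feature for which no measured step exists. A loss of similar or somewhat greater size is therefore expected: an 8.0-fold higher number from compound 2 to compound 4 (0.90 log units; beyond the scatter). Compound 4 is expected to give about 120 nM in this assay, within a range of 40 nM to 400 nM.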

Compound 4, half-maximal inhibitory concentration: 44 nM
Compound 4: middle estimate off by 2.7-fold (0.44 log units), on the high side, within the range that was stated.
By their numbers in this assay, from the lowest: compounds 1 and 2 (each within the scatter of the next); then compounds 4 and 3 (each within the scatter of the next).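

In this assay, the step of a 2.9-fold higher number from compound 2 to compound 4 (0.47 log units; beyond the scatter) shows that a second, different non-aromatic ring on the sulfonyl sulfur also gives a higher number than the 5-(trifluoromethyl)pyridin-3-yl group, and the step of a 5.5-fold higher number from compound 1 to compound 4 (0.74 log units; beyond the scatter) shows the same against 3-(trifluoromethyl)phenyl. The step of a 1.9-fold lower number from compound 3 to compound 4 (0.28 log units; within the scatter) lies within the scatter, so 4-hydroxypiperidin-1-yl and 1-acetylpiperidin-4-yl are not told apart, and the hydrogen-bond donor that enters with the hydroxypiperidine brings no separation from compound 3. Across these four compounds, the two with an aromatic ring on the sulfonyl sulfur thus stand apart from the two with a non-aromatic ring, and none of the four goes against this split.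

Nothing measured alongside these numbers accounts for the result.

The compounds shown leave open what the hydroxyl itself contributes, a question that plain piperidin-1-yl or morpholin-4-yl at this place would address. They also leave open whether an amine or a carboxylic acid on the same non-aromatic ring would shift the number, and whether an unsubstituted phenyl would stay with compound 1 and compound 2.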